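The source may hold more compounds than are shown below. What is called first, only, known or untested is meant among the compounds shown, and "the series" means these compounds.

Compounds measured in an assay on isolated protein for binding affinity to corticotropin-releasing factor receptor 1 (Homo sapiens); on this read-out lower numbers stand for stronger inhibition and higher numbers for weaker inhibition:
Compound 1 `C#Cc1cccc(/N=C(/NNc2ccccc2C)C(C)=O)c1` gives 62 nM.
Compound 2 `CC(=O)/C(=N\c1ccc(Cl)cc1)NNc1ccccc1C(F)(F)F` gives only a limit of the assay, > 10000 nM.
Compound 3 `CC(=O)/C(=N\c1cccc(C)c1)NNc1ccccc1C(F)(F)F` gives 1420 nM.

Among the numbers shown, compound 3 stands highest, that is, weakest. Among the measured compounds shown here, its nearest neighbour is compound 1, which differs from it in two places at once, the group on the double-bonded nitrogen and the substituent on the hydrazine-bearing ring, so the two values show only that this combined exchange leaves compound 1 far ahead. For the measured compounds named here, the single step confined to one place, an at least 7.0-fold lower number from compound 2 to compound 3 (0.84 log units; beyond the scatter), shows that the aryl group on the double-bonded nitrogen can move the number strongly; compound 2 sits at the limit of > 10000 nM in this assay, at which 1 of the 3 values shown sits, so the full size of that step is open.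

Compound 4 `C#Cc1cccc(/N=C(/NNc2ccccc2C(F)(F)F)C(C)=O)c1` differs from compound 3 by ethynyl in place of methyl on an aromatic carbon. Going by the values given here, no measured step isolates this exchange: compound 1 carries the ethynyl group, but on a different hydrazine partner, and its value cannot be read as the effect of the ethynyl alone. Among the compounds with values here, the change does fall on the ring where the one measured step was large, which argues for some movement rather than none.

Compound 4 is therefore expected in this assay to give about 700 nM, within 200 nM to 3000 nM. The estimated step of a 2.0-fold lower number from compound 3 to compound 4 (0.31 log units; beyond the scatter) is a modest gain, not securely beyond the scatter.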

Compound 4, inhibition constant: 66 nM
Beside the measured number, compound 4's estimate is 11-fold (1.03 log units) above it, and the stated range ends above it.
By their numbers in this assay, from the lowest: compounds 1 and 4 (each within the scatter of the next); then compound 3. At a limit, above all of these: compound 2.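

In this assay, a 22-fold lower number from compound 3 to compound 4 (1.33 log units; beyond the scatter) isolates the 3-methylphenyl to 3-ethynylphenyl exchange and shows a large gain from this one position on the aromatic ring, which compound 1 alone could not show, and 3-ethynylphenyl in place of 4-chlorophenyl gives an at least 150-fold lower number from compound 2 to compound 4 (2.18 log units; beyond the scatter). Among the compounds shown here, with the ethynyl group held fixed, a 1.1-fold higher number from compound 1 to compound 4 (0.03 log units; within the scatter) shows that trifluoromethyl and methyl on the hydrazine-bearing ring cannot be told apart in this pair, so the earlier compounds' trifluoromethyl group does not stand in the way of a low number. Compound 2 stands only at a limit of the assay, and the full size of the second step above stays open: the limit of > 10000 nM in this assay, at which 1 of the 4 values shown sits.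

An ethyl group or a nitrile in place of the ethynyl group would test whether the triple bond itself is needed for the gain. Also open, from the compounds shown here alone, is whether the ethynyl group keeps this gain in another place on the ring, and whether a methoxy group or a chlorine in place of the methyl or trifluoromethyl group on the hydrazine-bearing ring would be tolerated as well.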